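The compounds below may be only part of what the source reports. "The series", "measured", "known", "first", "only" and "open" are said of these compounds alone.

Compound 1, `Cc1cccc(OCCCOc2ccc(-c3ccccc3CCC(=O)NS(=O)(=O)c3cccs3)cc2)c1`: 4600 nM
Compound 2, `O=C(CCc1ccccc1-c1cccc(/C=C/c2ccc3ccc(Cl)cc3n2)c1)NS(=O)(=O)c1cccs1`: 49000 nM
Compound 3, `Cc1cccc(OCCCOc2ccc(-c3ccccc3CC(C)C(=O)NS(=O)(=O)c3cccs3)cc2)c1`: 5800 nM

All three were tested in an assay on isolated protein for binding affinity to prostaglandin E2 receptor EP1 subtype (Homo sapiens); a lower number here means a stronger inhibitor, a higher number a weaker inhibitor. Compound 3 shows the second highest of the three numbers, although compound 1 sits within the usual scatter of it, while compound 2 is much further away with a far higher number. Compound 4, `Cc1cccc(OCCCOc2ccc(-c3ccccc3CC(C)(C)C(=O)NS(=O)(=O)c3cccs3)cc2)c1`, differs from compound 3 by methyl in place of hydrogen on a saturated chain carbon bound to a carbonyl carbon and two saturated chain carbons. Among the measured compounds shown here, one measured step bears on this change: the earlier addition of a methyl at the same chain carbon gave a 1.3-fold higher number from compound 1 to compound 3 (0.10 log units; within the scatter). A second methyl there is therefore expected to produce at most a small shift, if any beyond the scatter, perhaps towards a slightly higher number. Compound 4 is thus estimated at 7500 nM, within a range of 2500 nM to 22000 nM. This amounts to an expected step of a 1.3-fold higher number from compound 3 to compound 4 (0.11 log units; within the scatter).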

Compound 4, inhibition constant: 1800 nM
Compound 4: middle estimate off by 4.2-fold (0.62 log units), on the high side, and the stated range ends above it.
By their numbers in this assay, from the lowest: compound 4; then compounds 1 and 3 (each within the scatter of the next); then compound 2.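

At this saturated chain carbon bound to a carbonyl carbon, the first methyl left the number within the scatter, with a 1.3-fold higher number from compound 1 to compound 3 (0.10 log units; within the scatter), whereas the second methyl gave a 3.2-fold lower number from compound 3 to compound 4 (0.51 log units; beyond the scatter). The effect of a methyl here therefore depends on what already sits on that carbon, so the two additions are not equal steps. Nothing measured here explains this difference.

On these data alone, whether an ethyl or a cyclopropyl ring at this carbon would give a similar number remains open. So does whether two methyls would shift the number on the core of compound 2.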